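A few compounds are considered here, and "the series" means these few. Any claim that something is new, unique, unknown or untested is made for them only; others in the source may bear on it.

Values in a functional assay on HCT-116 cells (Homo sapiens) for inhibition, read by MTT assay, with a stated time of 48 h; on this read-out lower numbers stand for stronger inhibition and higher numbers for weaker inhibition:
- compound 1 `COc1ccc(-n2c(SCc3ccccc3)nnc2-c2cc(OC)c(OC)c(OC)c2)cc1`: 42400 nM
- compound 2 `COc1ccc(-n2c(SCC(=O)C3CC3)nnc2-c2cc(OC)c(OC)c(OC)c2)cc1`: > 60000 nM (a limit of the assay, not a number)

Compound 2 stands at the limit of > 60000 nM in this assay, at which 1 of the 2 values shown sits, so its position is known only as a limit. Compound 3 `CCOC(=O)CSc1nnc(-c2cc(OC)c(OC)c(OC)c2)n1-c1ccc(OC)cc1` has not yet been measured. It differs from compound 2 by ethoxy in place of cyclopropyl on a carbonyl carbon, or cyclopropylcarbonyl to ethoxycarbonyl.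

Among the measured compounds shown here, one measured step bears on this, and only indirectly: an at least 1.4-fold higher number from compound 1 to compound 2 (0.15 log units; that floor lies within the scatter). For the measured compounds named here, that step is a floor rather than a size, and it concerns a different exchange, so no measured step covers a change on the carbonyl carbon itself. Going by the values given here, the expectation therefore rests on compound 1 at 42400 nM, the only true number available. It also rests on compound 2 at > 60000 nM, which is a limit of the assay.

No shift beyond the scatter is expected in this assay, and a direction cannot be assigned. The expected step is a number no higher from compound 2 to compound 3 (the limit leaves the size open). A report of only a limit would be no surprise. For compound 3 the estimated value is 60000 nM, with an expected range of 30000 nM to 120000 nM.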

Compound 3, half-maximal inhibitory concentration: > 60000 nM
Compound 3: only a limit was reported; the forecaster's own chance of this, stated with the estimate: 55%; the middle value sits exactly at the limit.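

In this assay, compound 3 gives > 60000 nM, a limit of the assay and not a number, so a second carbonyl-bearing group now ends at the same limit: the limit of > 60000 nM in this assay, at which 2 of the 3 values shown sit.

Ethoxycarbonyl in place of phenyl on the saturated chain carbon bound to a sulfur gives an at least 1.4-fold higher number from compound 1 to compound 3 (0.15 log units; that floor lies within the scatter), and this floor alone does not establish a real loss on leaving phenyl. The step from compound 2 to compound 3 cannot be read, so cyclopropyl and ethoxy on the carbonyl carbon cannot be told apart in this series.

Among the compounds shown here, compound 1, at 42400 nM, remains the only true number, which leaves open how far any group at this position can move the value in either direction. As far as these compounds go, it also remains open whether a carboxylic acid or a dimethylamino group on the carbonyl carbon, or a longer chain carrying the carbonyl, would give a true number rather than a limit.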